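This account rests on a few compounds, and the source may have more. Where it says the series, first, only, none or still open, it means among the compounds named here.

Measured in an ADME assay on microsomes from liver (Rattus norvegicus) for metabolic stability; on this read-out lower numbers stand for a shorter-lived compound and higher numbers for a longer-lived compound:
- compound 1 `COCCOc1cc2nccc(Oc3ccc(Nc4nccc5[nH]cc(-c6ccc(F)cc6)c(=O)c45)cc3F)c2cc1OC`: 1.06 h
- compound 2 `CC(O)COc1ccc2c(Oc3ccc(Nc4nccc5[nH]cc(-c6ccc(F)cc6)c(=O)c45)cc3F)ccnc2c1`: 1.42 h

Compound 2, at 1.42 h, stands within the scatter of compound 1, at 1.06 h, so the two cannot be told apart. Compound 3 `COCCOc1ccc2c(Oc3ccc(Nc4nccc5[nH]cc(-c6ccc(F)cc6)c(=O)c45)cc3F)ccnc2c1` differs from compound 2 by methoxymethyl in place of 1-hydroxyethyl on a saturated chain carbon bound to an oxygen on an aromatic ring. Among the measured compounds shown here, no measured pair isolates this change. The expected 1.2-fold lower number from compound 2 to compound 3 (0.07 log units; within the scatter) in this assay stays within the scatter. The estimated value for compound 3 is 1.2 h, with an expected range of 0.7 h to 2 h.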

Compound 3, half-life: 1.73 h
Compound 3: the middle estimate sits 1.4-fold (0.16 log units) below what was measured; the measured number falls inside the stated range.
By their numbers in this assay, from the lowest: compounds 1, 2 and 3 (each within the scatter of the next).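

In this assay, methoxymethyl in place of 1-hydroxyethyl on this chain removes the hydrogen-bond donor and gives a 1.2-fold higher number from compound 2 to compound 3 (0.09 log units; within the scatter), so compound 2 and compound 3 cannot be told apart. Hydrogen in place of methoxy on an aromatic carbon gives a 1.6-fold higher number from compound 1 to compound 3 (0.21 log units; within the scatter), the first one-place comparison at that carbon, and it too does not separate the compounds. Nothing available explains the size of either step.

On these data alone, whether an amine or a carboxylic acid at this chain end would leave the scatter remains open. The same holds for a longer chain.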